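Thiazole for Methylisoxazole on the Sulfonamide Nitrogen

The compounds below may be only part of what the source reports. "The series", "measured", "known", "first", "only" and "open" are said of these compounds alone.

Compound 2 `C=C1CC[C@@H]2[C@](C)(COC(C)=O)[C@H](OC(C)=O)CC[C@@]2(C)[C@H]1CC(Nc1ccc(S(=O)(=O)Nc2cc(C)on2)cc1)C1=CCOC1=O` gives 4340 nM in a functional assay on COLO 205 cells (Homo sapiens) for inhibition, read by sulforhodamine B assay, with a stated time of 48 h (a higher number here means a weaker inhibitor of growth, a lower number a stronger inhibitor of growth), the highest of the three numbers shown, though all three lie within the scatter of one another: compound 1 `C=C1CC[C@@H]2[C@](C)(COC(C)=O)[C@H](OC(C)=O)CC[C@@]2(C)[C@H]1CC(Nc1ccc(S(=O)(=O)Nc2ccc(Cl)nn2)cc1)C1=CCOC1=O` gives 3160 nM and compound 3 `C=C1CC[C@@H]2[C@](C)(COC(C)=O)[C@H](OC(C)=O)CC[C@@]2(C)[C@H]1CC(Nc1ccc(S(=O)(=O)Nc2ncccn2)cc1)C1=CCOC1=O` gives 3800 nM. The steps of a 1.4-fold higher number from compound 1 to compound 2 (0.14 log units; within the scatter) and a 1.1-fold lower number from compound 2 to compound 3 (0.06 log units; within the scatter) are both within the scatter, as is a 1.2-fold higher number from compound 1 to compound 3 (0.08 log units; within the scatter). Compound 4 `C=C1CC[C@@H]2[C@](C)(COC(C)=O)[C@H](OC(C)=O)CC[C@@]2(C)[C@H]1CC(Nc1ccc(S(=O)(=O)Nc2nccs2)cc1)C1=CCOC1=O` differs from compound 2 by 1,3-thiazol-2-yl in place of 5-methyl-1,2-oxazol-3-yl on a sulfonamide nitrogen. Each exchange of the ring on the sulfonamide nitrogen measured so far has left the number essentially unchanged, so a step no larger than the scatter is expected for a 1.1-fold lower number from compound 2 to compound 4 (0.04 log units; within the scatter). Compound 4 is therefore estimated at 4000 nM, with a range of 2200 nM to 7500 nM.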

Compound 4, concentration for total growth inhibition: 10500 nM
Compound 4: the middle estimate sits 2.6-fold (0.42 log units) below what was measured; the whole stated range lies below it.
By their numbers in this assay, from the lowest: compounds 1, 3 and 2 (each within the scatter of the next); then compound 4.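

The ring on the sulfonamide nitrogen is not indifferent in this assay: 1,3-thiazol-2-yl moves the number beyond the scatter, with a 2.4-fold higher number from compound 2 to compound 4 (0.38 log units; beyond the scatter) and a 2.8-fold higher number from compound 3 to compound 4 (0.44 log units; beyond the scatter) and also a 3.3-fold higher number from compound 1 to compound 4 (0.52 log units; beyond the scatter) as modest steps toward weaker growth inhibition. Compound 4 is thus the weakest of the four, while the other three rings remain indistinguishable. No measurement shown accounts for this separation.

The exchange of 5-methyl-1,2-oxazol-3-yl for 1,3-thiazol-2-yl alters the ring and removes its methyl together, so the two changes cannot be told apart here. From the compounds shown here alone, how a 5-methyl-1,3-thiazol-2-yl or a plain phenyl ring would fare remains open.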